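Extending a nitro-bearing aryl ether toward a biaryl

The compounds below may be only part of what the source reports. "The series", "measured", "known", "first", "only" and "open" are said of these compounds alone.

Compound 1, `CN1CCC[C@H]1COc1cccc([N+](=O)[O-])c1`: 31.2 nM in an assay on membranes from Cerebral cortex for displacement of a labelled ligand from Neuronal acetylcholine receptor; alpha4/beta2 (Rattus norvegicus), with a stated time of 30 min; a higher number here means a weaker inhibitor, a lower number a stronger inhibitor
Compound 2, `CN1CCC[C@H]1COc1cc(O)cc(-c2ccc(O)cc2)c1`: 3.8 nM in this assay
Compound 3, `CN1CCC[C@H]1COc1cc(Br)cc([N+](=O)[O-])c1`: 55 nM in this assay

Compound 3 has the highest of the three numbers in this assay. Its nearest neighbour is compound 1, which differs only by bromo in place of hydrogen on an aromatic carbon; that step, a 1.8-fold higher number from compound 1 to compound 3 (0.25 log units; within the scatter), lies within the scatter. Within the data shown here, compound 2 stands furthest away with the lowest number of the three, and it differs from compound 3 in two places, so no single step connects them.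

Compound 4, `CN1CCC[C@H]1COc1cc(-c2ccc(O)cc2)cc([N+](=O)[O-])c1`, is the next compound to be measured. The change from compound 3 is 4-hydroxyphenyl in place of bromo on an aromatic carbon. Among the measured compounds shown here, no measured step isolates this change. For the measured compounds named here, what can be drawn on is that compound 2, the only compound carrying the 4-hydroxyphenyl group, gives 3.8 nM, well below the numbers of compound 1 and compound 3, which lack it. On that basis compound 4 is expected to move toward a lower number than compound 3, with the step estimated as a 5.5-fold lower number from compound 3 to compound 4 (0.74 log units; beyond the scatter). Compound 4 is therefore estimated at 10 nM, with a range from 3 nM to 40 nM.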

Compound 4, inhibition constant: 12 nM
Beside the measured number, compound 4's estimate is 1.2-fold (0.08 log units) below it; the range from low to high includes it.
By their numbers in this assay, from the lowest: compound 2; then compound 4; then compounds 1 and 3 (each within the scatter of the next).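

In this assay, 4-hydroxyphenyl at this position, meta to the nitro group, gives a step beyond the scatter whether it replaces bromo (a 4.6-fold lower number from compound 3 to compound 4 (0.66 log units; beyond the scatter)) or hydrogen (a 2.6-fold lower number from compound 1 to compound 4 (0.41 log units; beyond the scatter)), whereas bromo in the same place left the number within the scatter (a 1.8-fold higher number from compound 1 to compound 3 (0.25 log units; within the scatter)). The position therefore tolerates a much larger group than bromo, and here the larger group gives the lower number. With 4-hydroxyphenyl held constant, the other substituent also counts, since nitro in place of hydroxy gives a modest step upward (a 3.2-fold higher number from compound 2 to compound 4 (0.50 log units; beyond the scatter)).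

The compounds shown leave open whether the step comes from the added ring or from its hydroxy group, which a plain phenyl or a 4-methoxyphenyl group at this position would separate. No measurement shown explains why either change moves the number.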